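A few compounds are considered here, and "the series" means these few. Any claim that something is new, unique, unknown or untested is made for them only; others in the source may bear on it.

Measured so far:
compound 1 `NC1=NC2(CCSCC2)N(OCCCOc2cccc(Cl)c2)C(N)=N1` — 130 nM
compound 2 `NC1=NC2(CCSCC2)N(OCCCOc2ccc(Cl)cc2)C(N)=N1` — 350 nM
compound 3 `NC1=NC2(CCSCC2)N(OCCCOc2cc(Cl)c(Cl)cc2Cl)C(N)=N1` — 110 nM

In a functional assay on MDA-MB-231 cells (Homo sapiens) for antiproliferative activity, read by MTT assay, with a stated time of 72 h (on this read-out higher numbers stand for weaker inhibition and lower numbers for stronger inhibition), compound 3 gives the lowest of the three numbers; its gap to compound 1 lies within the scatter, so no order can be read between these two, while compound 2 sits clearly higher, as a 3.2-fold lower number from compound 2 to compound 3 (0.50 log units; beyond the scatter) shows. Compound 4 `NC1=NC2(CCSCC2)N(OCCCOc2ccccc2Cl)C(N)=N1` is not yet measured. It differs from compound 3 in one place: 2-chlorophenyl in place of 2,4,5-trichlorophenyl on an oxygen on a saturated carbon. Going by the values given here, two measured steps bear on this change, each putting the 2,4,5-trichlorophenyl in place of a monochlorophenyl on an oxygen on a saturated carbon: a 1.2-fold lower number from compound 1 to compound 3 (0.07 log units; within the scatter) and a 3.2-fold lower number from compound 2 to compound 3 (0.50 log units; beyond the scatter). Read in reverse, going from the 2,4,5-trichlorophenyl to a monochlorophenyl left the number unchanged within the scatter in one case and raised it modestly in the other. Among the compounds with values here, no measured compound carries a 2-chlorophenyl, so this particular group is untested. For compound 4 the expected step is therefore a small-to-modest rise in the number, a 1.8-fold higher number from compound 3 to compound 4 (0.26 log units; within the scatter). Compound 4 is estimated at 200 nM, with a range from 80 nM to 500 nM.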

Compound 4, half-maximal inhibitory concentration: 80 nM
Beside the measured number, compound 4's estimate is 2.5-fold (0.40 log units) above it; low and high end bracket the measured number.
By their numbers in this assay, from the lowest: compounds 4, 3 and 1 (each within the scatter of the next); then compound 2.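

In this assay the 2-chlorophenyl on this oxygen performs on a par with the 2,4,5-trichlorophenyl, with a 1.4-fold lower number from compound 3 to compound 4 (0.14 log units; within the scatter), so the larger group is not needed for a number in this range, and the 3-chlorophenyl cannot be separated from it either, with a 1.6-fold lower number from compound 1 to compound 4 (0.21 log units; within the scatter). Only the 4-chlorophenyl stands apart, with a 4.4-fold lower number from compound 2 to compound 4 (0.64 log units; beyond the scatter), now the widest step in the set, yet a rule tying the higher number to chlorine at that ring position fails on compound 3, which keeps a low number with its 2,4,5-trichlorophenyl. Nothing at hand explains why compound 2 alone stands apart.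

Open, as far as these compounds go, is whether chlorine is needed at all, which an unsubstituted phenyl or a phenyl bearing methoxy or nitrile would test. Also open, from the compounds shown here alone, is how these differences hold with a longer chain between the two oxygens.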